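The source may report more compounds than this note shows. Statements on the series, on what has been measured and on what is new or still open speak of the compounds shown alone.

Among the measured compounds shown here, in a functional assay (muscle tissue) with Cavia porcellus as the target (on this read-out lower numbers stand for an effect already at smaller amounts and higher numbers for an effect only at larger amounts of compound), compound 1 (`COC(=O)C1=C(C)N=C(C)/C(=C(\O)OC)C1c1ccccc1N`) gives 39800 nM and stands highest of the three numbers so far. Compound 2 (`COC(=O)C1=C(C)N=C(C)/C(=C(\O)OC)C1c1cccc(O)c1`) gives 1000 nM and compound 3 (`COC(=O)C1=C(C)N=C(C)/C(=C(\O)OC)C1c1cccc(N)c1`) gives 2000 nM on the same read-out. These two lie within the scatter of each other, as a 2.0-fold higher number from compound 2 to compound 3 (0.30 log units; within the scatter) shows for amino in place of hydroxy on an aromatic carbon.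

Two large steps lead away from the top of the series: a 40-fold lower number from compound 1 to compound 2 (1.60 log units; beyond the scatter) and also a 20-fold lower number from compound 1 to compound 3 (1.30 log units; beyond the scatter) with a different substituted phenyl in each. The change to compound 4 (`CCOc1ccccc1C1C(C(=O)OC)=C(C)N=C(C)/C1=C(\O)OC`) is ethoxy in place of amino on an aromatic carbon, ortho to a large group (ethoxy in place of amino on an aromatic carbon). For the measured compounds named here, no measured step makes this exact exchange, so those large steps bear on it only loosely, and the uncertainty is wide.

The step expected in this assay is a 13-fold lower number from compound 1 to compound 4 (1.12 log units; beyond the scatter) as an estimate, toward a lower number. For compound 4 the expected value is 3000 nM with an estimated range from 300 nM to 30000 nM as the working span.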

Compound 4, half-maximal effective concentration: 110 nM
Compound 4: middle estimate off by 27-fold (1.44 log units), on the high side; measured number outside the range, below it.
By their numbers in this assay, from the lowest: compound 4; then compounds 2 and 3 (each within the scatter of the next); then compound 1.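

In this assay the exchange of amino for ethoxy gives a 360-fold lower number from compound 1 to compound 4 (2.56 log units; beyond the scatter), so the same aromatic carbon, ortho to a large group, now carries both the highest and the lowest number in the series. Until now this place was known only with amino, and the high number could have belonged to any substitution there; ethoxy shows that it does not. Nothing measured on hand accounts for the size of this step.

Still open, going by these compounds, is whether the oxygen or the two-carbon chain of ethoxy carries the step, which methoxy, hydroxy or a longer chain such as propoxy at this place would help to separate. Also open, on these data alone, is how ethoxy would read out on the aromatic carbon that carries hydroxy in compound 2 and amino in compound 3.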